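Fluoro for Hydrogen on the Phenyl Ring of Compound 2

The source may hold more compounds than are shown below. What is called first, only, known or untested is meant among the compounds shown, and "the series" means these compounds.

Of the compounds shown here, three of a shared core have been measured in a functional assay on the whole organism (strain Swiss) with Mus musculus as the target, in the maximal electroshock model, with a stated time of 1 h, at a dose of 100 mg/kg by the intraperitoneal route; a lower number here means a weaker effect, a higher number a stronger effect of the compound at the dose given. Compound 1 `COCC(C(=O)N1CCN(c2cccc(C(F)(F)F)c2)CC1)N1C(=O)CCC1=O` gives 50% in this assay. Compound 2 `CC(C(=O)N1CCN(c2ccccc2)CC1)N1C(=O)CCC1=O` gives 0%, and compound 3 `CCC(C(=O)N1CCN(c2cccc(F)c2)CC1)N1C(=O)CCC1=O` gives 0%. Compound 2 and compound 3 are level at the digits shown, together the lowest of the three, while compound 1 stands a number higher than compound 2 that lies beyond the usual scatter. Compound 4 `CC(C(=O)N1CCN(c2ccccc2F)CC1)N1C(=O)CCC1=O` is not yet measured; it differs from compound 2 by fluoro in place of hydrogen on an aromatic carbon. Within the data shown here, with no step between measured compounds that isolates this change, the step from compound 2 to compound 4 in this assay is expected to be small, a number 10 percentage points higher from compound 2 to compound 4 (within the scatter), not clearly beyond the scatter. Compound 4 is estimated at 10%, between 0% and 40%.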

Compound 4, a percentage reported as activity, at one dose (the size of the read-out at that dose, not a potency): 0%
Estimate against measurement, compound 4: 10 percentage points above, within the range that was stated.
By their numbers in this assay, from the lowest: compounds 2, 3 and 4 (each within the scatter of the next); then compound 1.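

In this assay, among these compounds, fluoro in place of hydrogen on an aromatic carbon, ortho to a large group, gives no change at the digits printed from compound 2 to compound 4 (within the scatter), the first step that isolates this change. At this position, then, phenyl to 2-fluorophenyl brings no effect that can be told from the scatter at the dose given. No measurement shown bears on why this is so.

Going by these compounds, it stays open whether an amine or a carboxylic acid on this same aromatic carbon would give a different read-out in this assay. On these data alone, it also stays open whether fluoro here would behave the same with a longer chain on the shared core.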